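Imidazole for thiophene on the benzylic aryl of compound 3

The compounds below may be only part of what the source reports. "The series", "measured", "known", "first", "only" and "open" are said of these compounds alone.

Working notes on a small set of ureas read in a functional assay on a cell-free system (plasma) with sterol O-acyltransferase, Soat (Rattus norvegicus) as the target; on this read-out higher numbers stand for an effect only at larger amounts of compound and lower numbers for an effect already at smaller amounts. Compound 1 `COc1ccccc1CN(Cc1cccc(-c2cc[nH]n2)c1)C(=O)Nc1c(SC)cc(C)nc1SC` gives only a limit of the assay, > 0.1 mg/kg. Compound 2 `O=C(Nc1c(F)cc(F)cc1F)N(Cc1ccc(-c2ccsc2)cc1)C1CCCCCC1` likewise gives only a limit, > 1 mg/kg. For the measured compounds named here, compound 3 `Cc1cc(C)c(NC(=O)N(Cc2ccc(-c3ccsc3)cc2)C2CCCCCC2)c(C)c1` is the one member with a number, 0.51 mg/kg, and so stands alone as the reference point. The other two entries are the limit of > 0.1 mg/kg in this assay, at which 1 of the 3 values shown sits, and the limit of > 1 mg/kg in this assay, at which 1 of the 3 values shown sits, rather than numbers. Going by the values given here, the one measured step, an at least 1.9-fold lower number from compound 2 to compound 3 (0.29 log units; that floor lies within the scatter), concerns the 2,4,6-trimethylphenyl in place of 2,4,6-trifluorophenyl on the amide-type nitrogen and rests on a limit, so its true size is open.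

Compound 4 `Cc1cc(C)c(NC(=O)N(Cc2ccc(-n3ccnc3)cc2)C2CCCCCC2)c(C)c1` keeps everything of compound 3 except the change (1H-imidazol-1-yl in place of thiophen-3-yl on an aromatic carbon). No measured step touches this position, and the step from compound 2 to compound 3 concerns a different part of the molecule, so nothing shown anticipates a shift beyond the scatter in this assay. The step from compound 3 to compound 4 is therefore expected to be small, a 1.4-fold higher number from compound 3 to compound 4 (0.14 log units; within the scatter). Compound 4 is expected to give about 0.7 mg/kg in this assay, within a range from 0.3 mg/kg to 2 mg/kg.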

Compound 4, dose for half-maximal effect: > 1 mg/kg
Compound 4: a limit, no number; the forecaster's own chance of this, stated with the estimate: 25%; middle value at least 1.4-fold (0.15 log units) away from the limit.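

For the compounds shown here, compound 4 gives the first measured step at this aromatic carbon, para to a large group, where 1H-imidazol-1-yl replaces thiophen-3-yl in this assay: an at least 1.9-fold higher number from compound 3 to compound 4 (0.29 log units; that floor lies within the scatter). The value of compound 4 is a limit and not a number: the limit of > 1 mg/kg in this assay, at which 2 of the 4 values shown sit. Going by these compounds alone, the exchange keeps the count of ring atoms and adds a second hetero atom and a second hydrogen-bond acceptor, yet it leaves compound 3 as the only member with a number, so this position cannot yet be treated as free to change, although the printed floor alone does not establish a shift beyond the scatter.

As far as these compounds go, the true size of the step stays open, as does whether the outcome follows the ring nitrogens of 1H-imidazol-1-yl or the loss of the sulfur of thiophen-3-yl. A plain phenyl ring, a thiazolyl ring, which keeps the sulfur and adds a ring nitrogen, or a pyrazol-1-yl ring on the same carbon would separate these readings, each read against compound 3.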